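The source may report more compounds than this note shows. Statements on the series, on what has been measured and on what is new or still open speak of the compounds shown alone.

Measured in a functional assay on A549 cells (Homo sapiens) for antiproliferative activity, read by sulforhodamine B assay, with a stated time of 3 days; a higher number here means a weaker inhibitor of growth, a lower number a stronger inhibitor of growth:
Compound 1 `O=C(Nc1ccc(C(F)(F)F)cc1)c1cccc(Nc2ncc(F)c(Nc3ccc(F)cc3)n2)c1`: > 10000 nM (a limit)
Compound 2 `COc1ccc(NC(=O)c2cccc(Nc3ncc(F)c(Nc4ccc(F)cc4)n3)c2)cc1`: 11000 nM
Compound 3 `O=C(Nc1cccc(Nc2ncc(F)c(Nc3ccc(F)cc3)n2)c1)c1ccccc1`: 37800 nM

Of the two true numbers in this assay, the higher belongs to compound 3, which makes it the weaker growth inhibitor of that pair. Compound 1 gives only a limit, > 10000 nM, and so cannot be ranked against compound 3.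

Compound 4 `O=C(Nc1cc(Cl)cc(Cl)c1)c1cccc(Nc2ncc(F)c(Nc3ccc(F)cc3)n2)c1` has (3,5-dichlorophenyl)carbamoyl in place of benzamido on an aromatic carbon.

The closest measured precedent is a 3.4-fold higher number from compound 2 to compound 3 (0.54 log units; beyond the scatter). That step joins benzamido to a different carbamoyl group, (4-methoxyphenyl)carbamoyl, and read backwards it points to a lower number on leaving compound 3. The other step, a step that the limit leaves unreadable from compound 1 to compound 2, gives no size, so it offers no guide to how much the substituents on the carbamoyl ring matter. Only compound 2 therefore sets the scale, and a modest move towards a lower number is expected, of about the size seen for compound 2. Compound 4 could also end as a limit, as the limit of > 10000 nM in this assay, at which 1 of the 3 values shown sits, shows for compound 1.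

The expected change is a 3.8-fold lower number from compound 3 to compound 4 (0.58 log units; beyond the scatter). For compound 4 the estimated value is 10000 nM, within an expected range of 3000 nM to 30000 nM.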

Compound 4, concentration for 50% growth inhibition: 17500 nM
Compound 4: the middle estimate sits 1.8-fold (0.24 log units) below what was measured; low and high end bracket the measured number.
By their numbers in this assay, from the lowest: compounds 2 and 4 (each within the scatter of the next); then compound 3.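

In this assay, the step of a 2.2-fold lower number from compound 3 to compound 4 (0.33 log units; beyond the scatter) gives a second case of a carbamoyl compound reading lower than the benzamido compound 3, so the earlier gap to compound 2 no longer rests on a single substituted ring. The new comparison between carbamoyl compounds, a 1.6-fold higher number from compound 2 to compound 4 (0.20 log units; within the scatter), shows that 3,5-dichlorophenyl and 4-methoxyphenyl on the amide-type nitrogen cannot be told apart here, even though the two rings carry different substituents. The step from compound 1 to compound 4 cannot be read, as compound 1 gives only a limit: the limit of > 10000 nM in this assay, at which 1 of the 4 values shown sits.

Because compound 3 differs from compounds 2 and 4 both in how its amide is attached and in lacking ring substituents, the compounds shown cannot separate these two changes; an unsubstituted phenylcarbamoyl group, or a benzamido group carrying methoxy or chlorine, would be needed to do so. Going by these compounds, it also remains open whether an amine or a carboxylic acid on the carbamoyl ring would move the number further than the methoxy and chlorine substituents do.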